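Methyl to ethyl: the next step in the series

A few compounds are considered here, and "the series" means these few. Any claim that something is new, unique, unknown or untested is made for them only; others in the source may bear on it.

In a functional assay on the whole organism (Myocardium) with Canis familiaris (Canis lupus familiaris) as the target (on this read-out lower numbers stand for an effect already at smaller amounts and higher numbers for an effect only at larger amounts of compound), compound 1 `CCC1C(=O)NN=C1c1ccc(-n2ccnc2)cc1` gives > 1 mg/kg, and this is a limit, not a number. Going by the values given here, compound 2 `CCC1(C)C(=O)NN=C1c1ccc(-n2ccnc2)cc1` gives 0.37 mg/kg, the only true number so far. One measured step exists: an at least 2.7-fold lower number from compound 1 to compound 2 (0.43 log units; beyond the scatter), with methyl in place of hydrogen on a saturated ring carbon, and it lies beyond the scatter. The size of that step is a bound only, since compound 1 sits at the limit of > 1 mg/kg in this assay, at which 1 of the 2 values shown sits. Compound 3 `CCC1(CC)C(=O)NN=C1c1ccc(-n2ccnc2)cc1` follows from compound 2 through methyl in place of hydrogen on a saturated chain carbon bound to a saturated ring carbon, in short methyl to ethyl: methyl in place of hydrogen on a saturated chain carbon bound to a saturated ring carbon. Among the compounds with values here, the one measured step sits at a different place, so it bears on this change only loosely and sets no firm direction. In this assay no step beyond the scatter is therefore expected. The estimated step is a 1.2-fold lower number from compound 2 to compound 3 (0.09 log units; within the scatter). For compound 3 the expected value is 0.3 mg/kg, with an estimated range from 0.1 mg/kg to 1 mg/kg.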

Compound 3, dose for half-maximal effect: > 1 mg/kg
Compound 3: no number, only a limit; the forecaster's own chance of this, stated with the estimate: 15%; middle value at least 3.3-fold (0.52 log units) from the limit.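

In this assay the methyl to ethyl change, on a saturated chain carbon bound to a saturated ring carbon, gives an at least 2.7-fold higher number from compound 2 to compound 3 (0.43 log units; beyond the scatter) and so goes against the small shift expected for it. Set beside an at least 2.7-fold lower number from compound 1 to compound 2 (0.43 log units; beyond the scatter), which points the opposite way, this shows that the one added carbon does not act in the same direction at each place: among the three compounds shown, the methyl and ethyl pair of compound 2 is the only substitution that gives a true number. From the compounds shown here alone, compound 3 stands at a limit, not a number, as compound 1 does, so the full size of the loss stays unknown, and the limit now marks most of the series: the limit of > 1 mg/kg in this assay, at which 2 of the 3 values shown sit.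

The step between the two compounds at the limit, compound 1 and compound 3, cannot be read, so the shown data do not rank them. Open too, going by these compounds, is whether the loss follows chain length alone, and how a propyl chain, a cyclopropyl group or a terminal amine at this place would read against compound 2.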